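From methylsulfonyl to (acetylcarbonyl)amino on the shared core

A few compounds are considered here, and "the series" means these few. Any claim that something is new, unique, unknown or untested is made for them only; others in the source may bear on it.

Three compounds sharing one core have been taken through a functional assay on HEK293 cells (Homo sapiens) for cytotoxicity; a lower number here means that less compound is tolerated, a higher number that more compound is tolerated: compound 1 `COc1ccc([C@H]2CC(=O)N(c3cccc(O)c3)C2)cc1OC1CCCC1`, compound 2 `COc1ccc([C@H]2CC(=O)N(c3cccc(N(C)C)c3)C2)cc1OC1CCCC1` and compound 3 `COc1ccc([C@H]2CC(=O)N(c3cccc(S(C)(=O)=O)c3)C2)cc1OC1CCCC1`. Compound 1 gives > 10000 nM, which is a limit and not a number. Compound 2 gives > 10000 nM, again a limit. Compound 3 gives > 10000 nM, also a limit, so it stands level with the other two only in that respect.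

Compound 4 `COc1ccc([C@H]2CC(=O)N(c3cccc(NC(=O)C(C)=O)c3)C2)cc1OC1CCCC1` carries (acetylcarbonyl)amino in place of methylsulfonyl on an aromatic carbon, meta to a large group: (acetylcarbonyl)amino in place of methylsulfonyl on an aromatic carbon.

Three measured changes on an aromatic carbon bear on this one: a step that the two limits leave unreadable from compound 1 to compound 2, a step that the two limits leave unreadable from compound 1 to compound 3 and a step that the two limits leave unreadable from compound 2 to compound 3. None has a readable size, and the common ground is the limit of > 10000 nM in this assay, at which 3 of the 3 values shown sit. On that basis, no change beyond the scatter is expected in either direction, and a further limit is the likeliest report.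

The expected step is a step that the limit leaves unreadable from compound 3 to compound 4. For compound 4 the estimate is 15000 nM, with an expected range from 6000 nM to 40000 nM.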

Compound 4, half-maximal cytotoxic concentration: > 10000 nM
Compound 4 ended at the assay's limit (the forecaster's own chance of this, stated with the estimate: 85%); the middle value is on the limit's open side.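

In this assay no new step can be read, since compound 4, like compounds 1, 2 and 3, is reported only as a limit. The compounds shown leave open whether these groups on the aromatic carbon differ at all, as every value stands at: the limit of > 10000 nM in this assay, at which 4 of the 4 values shown sit.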